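Dropping One Fluorine from the Difluorophenyl Furan Hydrazide

This account rests on a few compounds, and the source may have more. Where it says the series, first, only, none or still open, it means among the compounds named here.

Measured so far:
compound 1, `O=C(N/N=C/c1ccccc1O)c1ccc(-c2ccc(F)cc2)o1`, 63100 nM
compound 2, `O=C(N/N=C/c1ccc(-c2ccc(F)cc2F)o1)c1ccccc1O`, 125000 nM
compound 3, `COc1ccccc1/C=N/NC(=O)c1ccc(-c2ccc(F)cc2F)o1`, a limit of > 40000 nM

All three were tested in a functional assay on HL-60 cells (Homo sapiens) for antiproliferative activity, read by MTT assay, with a stated time of 48 h; on this read-out higher numbers stand for weaker inhibition and lower numbers for stronger inhibition. Compound 1 gives 63100 nM. Compound 2 gives 125000 nM, and this number and that of compound 1 lie within the usual scatter of each other, so no order between the two can be read. Compound 3 reaches only a limit, > 40000 nM, which is the limit described in the limit of > 40000 nM in this assay, at which 1 of the 3 values shown sits; it is not a number. Within the data shown here, no pair among the measured compounds differs in a single place, so no measured step is available.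

Compound 4, `O=C(N/N=C/c1ccc(-c2ccc(F)cc2)o1)c1ccccc1O`, has not yet been measured. It differs from compound 2 by hydrogen in place of fluoro on an aromatic carbon. Among the measured compounds shown here, with no comparable step to lean on, the expected step of a 1.1-fold lower number from compound 2 to compound 4 (0.06 log units; within the scatter) is no larger than the scatter. Compound 4 is therefore expected to give 110000 nM, in a range from 40000 nM to 320000 nM, because compound 2 gives 125000 nM in this assay.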

Compound 4, half-maximal inhibitory concentration: 61600 nM
Compound 4: the middle estimate sits 1.8-fold (0.25 log units) above what was measured; low and high end bracket the measured number.
By their numbers in this assay, from the lowest: compounds 4, 1 and 2 (each within the scatter of the next, the first and the last beyond it).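

In this assay, among these compounds, the change from 2,4-difluorophenyl to 4-fluorophenyl gives a 2.0-fold lower number from compound 2 to compound 4 (0.31 log units; beyond the scatter) as the first step in a single place. The fluoro group on the aromatic carbon ortho to a large group is therefore not required for the activity seen here: with hydrogen in its place the number falls rather than rises, though the step is modest. Compound 3 remains a limit and not a number, so it cannot be set against this step: the limit of > 40000 nM in this assay, at which 1 of the 4 values shown sits.

The compounds shown leave open whether chloro, an amine or a carboxylic acid on this same carbon would move the number further in either direction. They also leave open whether replacing the remaining fluoro group with hydrogen would give a step of similar size.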